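The compounds below may be only part of what the source reports. "The series", "measured", "known", "first", "only" and "open" are said of these compounds alone.

Compound 1 `CCCCCCCc1coc(=O)c(C)c1O`: 2200000 nM
Compound 2 `CCC(C)CCCCc1coc(=O)c(C)c1OC`: 1550000 nM

In an ADME assay on MDCK cells (Canis lupus familiaris) for cytotoxicity, read by crystal violet staining, with a stated time of 48 h (on this read-out higher numbers stand for lower toxicity in this test and lower numbers for higher toxicity in this test), compound 2 gives the lowest of the two numbers, and compound 1 lies within the usual scatter of it, so the two cannot be told apart on this read-out. Compound 3 `CCCCCCCc1coc(=O)c(C)c1OC` differs from compound 2 by hydrogen in place of methyl on a saturated chain carbon bound to two saturated chain carbons. Going by the values given here, no measured pair shows this change on its own, so in this assay no step beyond the scatter is expected in either direction. Compound 3 is therefore expected to give 1800000 nM, within 900000 nM to 3600000 nM. The expected step of a 1.2-fold higher number from compound 2 to compound 3 (0.06 log units; within the scatter) should stay inside the scatter of repeated measurements.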

Compound 3, half-maximal cytotoxic concentration: 2230000 nM
Estimate against measurement, compound 3: 1.2-fold (0.09 log units) below; the range from low to high includes it.
By their numbers in this assay, from the lowest: compounds 2, 1 and 3 (each within the scatter of the next).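

Hydrogen in place of methyl on a saturated chain carbon bound to two saturated chain carbons can now be read on its own in this assay (a 1.4-fold higher number from compound 2 to compound 3 (0.16 log units; within the scatter)), and the branched and unbranched chains cannot be told apart. Methyl in place of hydrogen on an oxygen on an aromatic ring can also be read on its own (a 1.0-fold higher number from compound 1 to compound 3 (0.01 log units; within the scatter)), and it too leaves the compounds indistinguishable. Nothing available explains either result. Still open, going by these compounds, is whether an amine or a carboxylic acid at either place, or a longer chain, would give a step beyond the scatter.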